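This account rests on a few compounds, and the source may have more. Where it says the series, first, only, none or still open, it means among the compounds named here.

Compound 1 `Nc1ncnc2c1c(-c1cnc3[nH]ccc3c1)nn2CC(=O)NO` and compound 2 `Nc1ncnc2c1c(-c1cnc3[nH]ccc3c1)nn2CCCCC(=O)NO` share one core, and compound 3 `Nc1nc2cc(-c3nn(CCCCCC(=O)NO)c4ncnc(N)c34)ccc2o1` with compound 4 `Nc1nc2cc(-c3nn(CCCCCCCCC(=O)NO)c4ncnc(N)c34)ccc2o1` another; the difference between the two cores is not broken down here. All were, or are to be, tested in a functional assay on A549 cells (Homo sapiens) for inhibition, read by MTT assay, with a stated time of 72 h; on this read-out higher numbers stand for weaker inhibition and lower numbers for stronger inhibition.

Compound 1 gives only a limit in this assay, > 150000 nM. Compound 2 likewise gives only a limit, > 150000 nM. The change from compound 1 to compound 2 is 3-(hydroxycarbamoyl)propyl in place of hydroxycarbamoyl on a saturated chain carbon bound to an aromatic nitrogen. Its step, a step that the two limits leave unreadable from compound 1 to compound 2, cannot be read, since both ends are limits; two of the three values shown sit at the limit of > 150000 nM in this assay, at which 2 of the 3 values shown sit.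

For the measured compounds named here, compound 3 gives only a limit in this assay, > 100000 nM; it is the one value at the limit of > 100000 nM in this assay, at which 1 of the 3 values shown sits. Compound 4 carries the same kind of change relative to compound 3, namely (3-(hydroxycarbamoyl)propyl in place of hydroxycarbamoyl on a saturated chain carbon, five bonds along the chain from an aromatic nitrogen), but the place differs: here the chain carbon is five bonds along the chain from an aromatic nitrogen, whereas in compound 2 it is bound to an aromatic nitrogen.

Since neither end of the earlier step was measurable, and compound 3 itself stands at a limit, compound 4 is expected to remain without a readable number as well; the expected step is a step that the limit leaves unreadable from compound 3 to compound 4, which rests on the limits of compound 1, compound 2 and compound 3. The estimate for compound 4 is 150000 nM, expected to fall between 50000 nM and 400000 nM.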

Compound 4, half-maximal inhibitory concentration: 13200 nM
Compound 4: the middle estimate sits 11-fold (1.06 log units) above what was measured; measured number below the stated range.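

On the core of compound 3, 3-(hydroxycarbamoyl)propyl in place of hydroxycarbamoyl, on a saturated chain carbon five bonds along the chain from an aromatic nitrogen, gives in this assay an at least 7.5-fold lower number from compound 3 to compound 4 (0.87 log units; beyond the scatter), so on this core and at this place the change does lower the number beyond the scatter. The step of the same kind on the core of compound 1 cannot be read, and that pair offers no size to set beside the new one: the limit of > 150000 nM in this assay, at which 2 of the 4 values shown sit. The new step therefore shows the change at work in a single pair on a single core, and it does not show that the change carries from one core to the other, or that it fails to, since the two changes also sit at different places on the chain.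

The compounds shown leave open whether the chain of compound 4, carried onto the core of compound 1, would give a readable number in this assay. They also leave open whether a longer chain than that of compound 4 would lower the number further, and whether a carboxylic acid or an amine in place of the hydroxycarbamoyl end would keep the number of compound 4.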